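Notes on the methyl step from compound 3

The source may report more compounds than this note shows. Statements on the series, on what has been measured and on what is new or still open speak of the compounds shown alone.

Measured in a functional assay on NCI-H1975 cells (Homo sapiens) for inhibition, read by MTT assay, with a stated time of 72 h; on this read-out higher numbers stand for weaker inhibition and lower numbers for stronger inhibition:
compound 1 `CCN1CCN(c2cc(C(F)(F)F)nc(SCc3ccc(C(F)(F)F)cc3)n2)CC1`: 15000 nM
compound 2 `FC(F)(F)c1ccc(CSc2nc(Sc3ccccn3)cc(C(F)(F)F)n2)cc1`: 23900 nM
compound 3 `FC(F)(F)c1ccc(CSc2nc(Sc3nncs3)cc(C(F)(F)F)n2)cc1`: 2270 nM

Compound 3 has the lowest number of the three. Compound 4 `Cc1nnc(Sc2cc(C(F)(F)F)nc(SCc3ccc(C(F)(F)F)cc3)n2)s1` differs from it as follows: methyl in place of hydrogen on an aromatic carbon. This is methyl in place of hydrogen on an aromatic carbon. Going by the values given here, no measured step tests this change directly. The closest are an 11-fold lower number from compound 2 to compound 3 (1.02 log units; beyond the scatter) and a 6.6-fold lower number from compound 1 to compound 3 (0.82 log units; beyond the scatter), both replacing the whole group rather than adding to it, so they give no direction for a methyl. A much smaller change is therefore expected in this assay, with no step beyond the scatter. The estimate is a 1.1-fold higher number from compound 3 to compound 4 (0.04 log units; within the scatter). Compound 4 is expected at 2500 nM, with an estimated range of 900 nM to 7000 nM.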

Compound 4, half-maximal inhibitory concentration: 3060 nM
Estimate against measurement, compound 4: 1.2-fold (0.09 log units) below, and the stated range covers the measured number.
By their numbers in this assay, from the lowest: compounds 3 and 4 (each within the scatter of the next); then compounds 1 and 2 (each within the scatter of the next).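

In this assay, methyl in place of hydrogen on the aromatic carbon of the 1,3,4-thiadiazol-2-yl group gives a 1.3-fold higher number from compound 3 to compound 4 (0.13 log units; within the scatter) and so leaves the number unchanged within the scatter. This position therefore accepts a methyl, and the 5-methyl-1,3,4-thiadiazol-2-yl group keeps the separation from the other groups, with a 7.8-fold lower number from compound 2 to compound 4 (0.89 log units; beyond the scatter) and a 4.9-fold lower number from compound 1 to compound 4 (0.69 log units; beyond the scatter) both beyond the scatter. As far as these compounds go, whether an amine, a carboxylic acid or a longer chain on this carbon would hold the number stays open, since a single methyl sets no trend. Nothing available bears on why the methyl is accepted here.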